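Amide to urea on the anilide of compound 1

The source may hold more compounds than are shown below. What is called first, only, known or untested is meant among the compounds shown, and "the series" means these compounds.

Compound 1, `COc1cc(-c2nn(-c3cccc(NC(=O)c4cccc(C(F)(F)F)c4)c3)cc2-c2ccncc2)ccc1Cl`, is measured in a functional assay on MOLT-4 cells (Homo sapiens) for inhibition, read by sulforhodamine B assay, with a stated time of 48 h (a higher number here means a weaker inhibitor of growth, a lower number a stronger inhibitor of growth), where compound 1 gives 2010 nM. Compound 2, `O=C(Nc1cccc(-n2cc(-c3ccncc3)c(-c3ccc(Cl)c(O)c3)n2)c1)Nc1cc(C(F)(F)F)cc(C(F)(F)F)c1`, is also measured in this assay; compound 2 gives 1150 nM, a number that lies within the usual scatter of that of compound 1, so the two are not told apart. Compound 3, `COc1cc(-c2nn(-c3cccc(NC(=O)Nc4ccc(Cl)c(C(F)(F)F)c4)c3)cc2-c2ccncc2)ccc1Cl`, differs from compound 1 by (4-chloro-3-(trifluoromethyl)phenyl)amino in place of 3-(trifluoromethyl)phenyl on a carbonyl carbon, a change that puts a hydrogen-bond donor on the carbonyl carbon. Among the measured compounds shown here, no measured pair shows this step, and only a small move toward a lower number, hardly beyond the scatter, is expected as a 1.5-fold lower number from compound 1 to compound 3 (0.19 log units; within the scatter). Compound 3 is therefore estimated at 1300 nM, with a range from 450 nM to 3800 nM.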

Compound 3, concentration for 50% growth inhibition: 1020 nM
Beside the measured number, compound 3's estimate is 1.3-fold (0.11 log units) above it; low and high end bracket the measured number.
By their numbers in this assay, from the lowest: compounds 3, 2 and 1 (each within the scatter of the next).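

In this assay, putting (4-chloro-3-(trifluoromethyl)phenyl)amino in place of 3-(trifluoromethyl)phenyl on a carbonyl carbon gives a 2.0-fold lower number from compound 1 to compound 3 (0.29 log units; within the scatter). Among the compounds shown here, this is the first direct reading at this position, and it shows that the exchange leaves growth inhibition within the scatter. Nothing available accounts for this step.

Going by these compounds, the amino link and the chlorine enter together, so their separate contributions remain open. On these data alone, how a dimethylamino group or a morpholine on this carbonyl carbon would read also stays unknown.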